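The source may report more compounds than this note shows. Statements on the series, on what has been measured and on what is new or still open speak of the compounds shown alone.

Three compounds that share a core and differ in the group on the oxygen have been measured in a physicochemical assay for lipophilicity; on this read-out higher numbers stand for higher lipophilicity and lower numbers for lower lipophilicity. Compound 1 `C=CC(C)(C)OC[n+]1ccn(C)c1/C=N/O` gives -1.54 and compound 2 `C=C(C)CCOC[n+]1ccn(C)c1/C=N/O` gives -1.41, a small difference: a number 0.13 log units higher from compound 1 to compound 2 (within the scatter). Compound 3 `C#CC(C)OC[n+]1ccn(C)c1/C=N/O` stands lowest of the three at -2.14, clearly apart from the other two.

Compound 4 `CC#CC(C)OC[n+]1ccn(C)c1/C=N/O` has not been measured yet. It differs from compound 3 in a single place, with methyl in place of hydrogen on a triple-bonded carbon, so ethynyl becomes prop-1-yn-1-yl.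

Among the compounds with values here, no measured pair shows this exact change, so the evidence is indirect. The closest guides are the two steps that end at compound 3: a number 0.60 log units lower from compound 1 to compound 3 (beyond the scatter), and a number 0.73 log units lower from compound 2 to compound 3 (beyond the scatter). Both replace the whole group on the oxygen, and read in reverse, both are modest rises away from compound 3. Adding one methyl is a smaller edit than either replacement, so a rise of similar or slightly smaller size seems a reasonable expectation. The expected step is a number 0.49 log units higher from compound 3 to compound 4 (beyond the scatter). For compound 4 the estimated value is -1.65, with an expected range from -1.95 to -1.35.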

Compound 4, distribution coefficient: -1.74
Compound 4: middle estimate off by 0.09 log units, on the high side, within the range that was stated.
By their numbers in this assay, from the lowest: compound 3; then compounds 4, 1 and 2 (each within the scatter of the next, the first and the last beyond it).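

In this assay, within the data shown here, this is the first direct reading of the change at this place: methyl in place of hydrogen on a triple-bonded carbon, turning ethynyl into prop-1-yn-1-yl, gives a number 0.40 log units higher from compound 3 to compound 4 (beyond the scatter), so a single added methyl is enough to move the number by more than repeat measurements would. The step also changes how compound 4 stands against the other two: there is a number 0.20 log units lower from compound 1 to compound 4 (within the scatter), yet still a number 0.33 log units lower from compound 2 to compound 4 (beyond the scatter), although the group on the oxygen has the same count of heavy atoms, all carbon and with no ring, in all three compounds. Thus the count alone does not settle the number here, and nothing measured alongside these compounds offers a reason for these steps.

As far as these compounds go, it stays open whether a longer chain in that place, such as ethyl or propyl in place of the methyl, would carry the number further, or whether a hydroxymethyl group or an amine there would move it the other way. From the compounds shown here alone, the change is also seen on one pair only, so its size with a different group on the oxygen remains unknown.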